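The compounds below may be only part of what the source reports. "The series", "measured", "known", "first", "only" and "open" are said of these compounds alone.

Compound 1 `CN1CCC=C(c2ccc(CN(C)Cc3ccc(Cl)cc3)cc2)C1` was examined in an ADME assay on HL-60 cells (Homo sapiens) for cytotoxicity, read by MTT assay, with a stated time of 24 h; on this read-out higher numbers stand for weaker inhibition and lower numbers for stronger inhibition. In this assay compound 1 gives only a limit of the assay, > 50000 nM. Compound 2 `CN1CCC=C(c2ccc(CN(C)C/C=C/c3ccccc3)cc2)C1` carries one change: 2-phenylethenyl in place of 4-chlorophenyl on a saturated chain carbon bound to an amine nitrogen. In this assay compound 2 likewise gives only a limit, > 50000 nM. Both values sit at the limit of > 50000 nM in this assay, at which 3 of the 3 values shown sit, so the step that the two limits leave unreadable from compound 1 to compound 2. Compound 3 `CN(Cc1ccc(Cl)cc1)Cc1ccc(C2CCCN(C)C2)cc1` differs from compound 1 in its core: a group of 7 heavy atoms (6 carbon, 1 nitrogen; one six-membered non-aromatic ring with 1 hetero atom) in place of a group of 7 heavy atoms (6 carbon, 1 nitrogen; one six-membered non-aromatic ring with 1 hetero atom), on an aromatic carbon. In this assay compound 3 also gives only a limit, > 50000 nM. The step that the two limits leave unreadable from compound 1 to compound 3. Compound 4 `CN(C/C=C/c1ccccc1)Cc1ccc(C2CCCN(C)C2)cc1`, not yet measured, bears the same change as compound 2, now on the core of compound 3: 2-phenylethenyl in place of 4-chlorophenyl on a saturated chain carbon bound to an amine nitrogen. Within the data shown here, because compound 3 gives only a limit, > 50000 nM, and because all values so far sit at the limit of > 50000 nM in this assay, at which 3 of the 3 values shown sit, the step that the limit leaves unreadable from compound 3 to compound 4 is expected to be small. Compound 4 is estimated at 60000 nM, most likely again reported only as a limit.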

Compound 4, half-maximal inhibitory concentration: > 50000 nM
Compound 4 was reported as a limit; the forecaster's own chance of this, stated with the estimate: 85%; the middle value is on the limit's open side.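

In this assay compound 4 gives only a limit, > 50000 nM, so neither its step from compound 2 nor its step from compound 3 can be read. Whether either change shifts the value at all stays open, because every compound shown sits at the same point: the limit of > 50000 nM in this assay, at which 4 of the 4 values shown sit.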